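The compounds below may be only part of what the source reports. "The series", "measured", "known", "first", "only" and "open" are said of these compounds alone.

Measured compounds:
- Compound 1 `CC/C(Nc1ccc(CN2CCCCC2)cc1)=C1/C(=O)Nc2ccc(NS(=O)(=O)CC)cc21` — > 6 uM
- Compound 2 `CS(=O)(=O)Nc1ccc2c(c1)/C(=C(/Nc1ccc(CN3CCCCC3)cc1)c1ccccc1)C(=O)N2` — 0.2 uM
- Compound 3 `CCS(=O)(=O)Nc1ccc2c(c1)/C(=C(/NC1CCN(C)CC1)c1ccccc1)C(=O)N2` — > 10 uM

Among the measured compounds shown here, in an ADME assay on HepG2 cells (Homo sapiens) for cytotoxicity, read by MTT assay, with a stated time of 48 h (on this read-out higher numbers stand for lower toxicity in this test and lower numbers for higher toxicity in this test), compound 2 gives 0.2 uM, the only actual number among the three values shown. For compound 1 the entry > 6 uM is a limit of the assay, not a number. For compound 3 the entry > 10 uM is likewise a limit. For the measured compounds named here, compound 2 therefore stands as the one compound with a measured toxic concentration in this set; the other two share no single-point difference with it, so their values say nothing direct about any one change.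

Compound 4 `CC(=O)Nc1ccc2c(c1)/C(=C(/Nc1ccc(CN3CCCCC3)cc1)c1ccccc1)C(=O)N2` differs from compound 2 in one place: acetyl in place of methylsulfonyl on a nitrogen on an aromatic ring. Going by the values given here, no measured pair shows this change, so no step size is known for it. A change from compound 2 to compound 4 of about a 2.0-fold higher number from compound 2 to compound 4 (0.30 log units; within the scatter) is expected, a shift that stays close to the scatter. For compound 4 the estimate is 0.4 uM, with a range from 0.1 uM to 2 uM.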

Compound 4, half-maximal toxic concentration: > 6 uM
Compound 4 ended at the assay's limit (the forecaster's own chance of this, stated with the estimate: 15%); middle value at least 15-fold (1.17 log units) away from the limit.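

Among the compounds shown here, this is the first comparison here in which only one place changes, and it shows that the group at this position matters: acetyl in place of methylsulfonyl on a nitrogen on an aromatic ring gives an at least 30-fold higher number from compound 2 to compound 4 (1.47 log units; beyond the scatter). In this assay compound 4 gives > 6 uM, which is a limit and not a number: the limit of > 6 uM in this assay, at which 2 of the 4 values shown sit. The shared core alone therefore does not set the low number of compound 2, since the group on this nitrogen shifts it strongly.

As far as these compounds go, whether a plain amine or a longer acyl chain at this nitrogen would behave like acetyl or like methylsulfonyl remains open.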